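Opening the Lactone Side Chain of an Imidazole Thioether

A few compounds are considered here, and "the series" means these few. Any claim that something is new, unique, unknown or untested is made for them only; others in the source may bear on it.

Measured so far:
- compound 1, `C[C@@]1(O)CC(=O)OC(CSc2nc(-c3ccc(Cl)cc3)c(-c3ccc(Cl)cc3)[nH]2)C1`: 180 nM
- compound 2, `CC1(C)CC(=O)OC(CSc2nc(-c3ccccc3)c(-c3ccccc3)[nH]2)C1`: 100 nM

Both compounds were tested in an assay on microsomes from liver for inhibition of sterol O-acyltransferase 1 (Rattus norvegicus); a higher number here means a weaker inhibitor, a lower number a stronger inhibitor. Compound 1 gives 180 nM and compound 2 gives 100 nM. Compound 2 has the lower of the two numbers, but the gap to compound 1 lies within the scatter of repeated measurements, so the two cannot be told apart on these data.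

Compound 3, `CCOC(CCSc1nc(-c2ccccc2)c(-c2ccccc2)[nH]1)OCC`, has not yet been measured. It differs from compound 2 in one place: a group of 8 heavy atoms (6 carbon, 2 oxygen; no ring) in place of a group of 9 heavy atoms (7 carbon, 2 oxygen; one six-membered non-aromatic ring with 1 hetero atom), on a saturated chain carbon bound to a sulfur. The ring that carries the lactone is gone, and an open chain with two ethoxy groups on one carbon sits there instead. Among the compounds with values here, with only two measured compounds and no measured step between them, there is nothing to show how this part of the molecule matters. The expectation is therefore a modest move, if any: compound 3 is estimated to give 200 nM in this assay, between 60 nM and 700 nM, a step of a 2.0-fold higher number from compound 2 to compound 3 (0.30 log units; within the scatter) that is expected to lean toward a weaker inhibitor but may stay within the scatter.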

Compound 3, half-maximal inhibitory concentration: 69 nM
Estimate against measurement, compound 3: 2.9-fold (0.46 log units) above; low and high end bracket the measured number.
By their numbers in this assay, from the lowest: compounds 3, 2 and 1 (each within the scatter of the next, the first and the last beyond it).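

In this assay, within the data shown here, replacing the ring that carries the lactone with the open 2,2-diethoxyethyl group gives a 1.4-fold lower number from compound 2 to compound 3 (0.16 log units; within the scatter), the first measured step at this place, on a saturated chain carbon bound to a sulfur. The ring is therefore not needed to keep inhibition in this range: a group with no ring, one heavy atom smaller and with the same count of hydrogen-bond acceptors, cannot be told apart from it in this assay. No measurement at hand says why the two groups read alike.

Among these compounds, with only this one step, it remains open how much of the side chain matters, since neither group shows what happens when the oxygen atoms are absent, and a plain butyl chain, a carboxylic acid or an amine at this place could either hold the number or move it beyond the scatter. From the compounds shown here alone, it is also open whether the same exchange would read the same way on the core of compound 1, which carries a different substitution from compound 2 and compound 3.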